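The source may report more compounds than this note shows. Statements on the series, on what has been measured and on what is new or still open speak of the compounds shown alone.

Working notes on the series. Two compounds carry a result in an assay on HEK293-A cells for agonist activity at probable G-protein coupled receptor 34 (Mus musculus), with a stated time of 1.5 h; on this read-out higher numbers stand for larger maximal responses and lower numbers for smaller maximal responses. Compound 1, `N[C@@H](COP(=O)(O)OC[C@H]1OCCC[C@H]1OC(=O)CCc1ccc(OCc2cccc(Oc3ccccc3)c2)cc1)C(=O)O`, is recorded in this assay as "not active" (no number reported), with no number attached to the entry. Going by the values given here, compound 2, `CCCCCCCCCCCOc1ccccc1CCC(=O)OC[C@H]1OCC=C[C@H]1OP(=O)(O)OC[C@H](N)C(=O)O`, gives 5% in this assay, a small maximal response; this is the only number so far, and it stands beside a single further entry that has no number at all. Compound 3, `CCCCCCCCCCCOc1ccccc1CCC(=O)OC[C@H]1OCC=C[C@@H]1OP(=O)(O)OC[C@H](N)C(=O)O`, has not yet been measured in this assay. Relative to compound 2, the change is the two compounds have the same atoms and bonds; at least one stereo element is drawn with a configuration in one of them and without one in the other: 1 of 4 stereo elements differ; a stereocentre at a saturated ring carbon is drawn R in compound 2 and S in compound 3. Among the compounds with values here, no step between two measured compounds is available, so the size of the effect of this change cannot be read from the data, and whether the configuration at that ring carbon matters for the maximal response is open. The expected step is a number 7 percentage points higher from compound 2 to compound 3 (within the scatter), which may amount to nothing beyond the scatter or to a moderate rise. Compound 3 is therefore estimated to give 12% in this assay, within a range from 0% to 45%.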

Compound 3, largest response reached (Emax), in percent of the reference or control that the assay uses: < 3%
Compound 3: a limit, no number; the forecaster's own chance of this, stated with the estimate: 30%; middle value at least 9 percentage points from the limit.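

In this assay, going by these compounds alone, the stereocentre at a saturated ring carbon, drawn R in compound 2 and S in compound 3, now gives the first step, a number at least 2 percentage points lower from compound 2 to compound 3 (that floor lies within the scatter), so this change shows no shift in maximal response beyond the scatter. Compound 3 gives < 3%, which is a limit of the assay and not a number. The step therefore has only a floor and no exact size, and the comparison rests on this limit: the limit of < 3% in this assay, at which 1 of the 3 values shown sits.

Going by these compounds, whether the configuration at this ring carbon can matter at all stays open, since both compounds sit so low in this assay that any effect on a larger maximal response would not show in this pair. Also open, on these data alone, is whether a phosphonate in place of the phosphate, or a longer chain on the shared core, would bring a clear maximal response and so allow the two configurations to be told apart.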